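The source may report more compounds than this note shows. Statements on the series, on what has been measured and on what is new or still open speak of the compounds shown alone.

Measured compounds:
compound 1 `CCOC(=O)N1CCC(=NNC(=O)c2ccc([N+](=O)[O-])cc2[N+](=O)[O-])CC1`, 117000 nM
compound 2 `O=C(NN=C1CC(c2ccccc2)NC(c2ccccc2)C1)c1ccccc1`, 238000 nM

The study reads inhibition in a functional assay, read by spectrophotometry; a higher number here means a weaker inhibitor, a lower number a stronger inhibitor. Compound 1 gives 117000 nM, and compound 2 gives 238000 nM. Compound 2 thus stands at the higher of the two numbers, the weaker of the two inhibitors; its nearest neighbour is compound 1, whose number is lower, and the gap between them lies beyond the usual scatter. The two share no single-point change, so the comparison says only what the two values show.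

Compound 3 `O=C(NN=C1CC(c2ccccc2)NC(c2ccccc2)C1)c1ccc([N+](=O)[O-])cc1` has not yet been measured in this assay. It is reached from compound 2 by one change: nitro in place of hydrogen on an aromatic carbon. Within the data shown here, whether this change helps or hurts is not told by any step between measured compounds, and the only other nitro-bearing compound, compound 1, differs from compound 2 in many places at once. A step from compound 2 to compound 3 of modest size, not clearly beyond the scatter, is therefore expected in this assay. The estimated step is a 1.5-fold lower number from compound 2 to compound 3 (0.17 log units; within the scatter). Compound 3 is expected to give 160000 nM, within a range from 50000 nM to 500000 nM.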

Compound 3, half-maximal inhibitory concentration: 170000 nM
Compound 3: middle estimate off by 1.1-fold (0.03 log units), on the low side; the measured number falls inside the stated range.
By their numbers in this assay, from the lowest: compounds 1, 3 and 2 (each within the scatter of the next, the first and the last beyond it).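

In this assay, the change from phenyl to 4-nitrophenyl gives the first step read between two measured compounds that differ in one place: a 1.4-fold lower number from compound 2 to compound 3 (0.15 log units; within the scatter). Placing nitro, with its 3 heavy atoms, on this aromatic carbon, para to a large group, therefore does not separate the two compounds in this assay, an answer that the earlier pair, which differ in many places at once, could not give. No independent measurement bears on why the two values stay so close, and the result rests on this single pair of compounds.

As far as these compounds go, whether this position can respond more strongly to a different substituent stays open, since an amine, a carboxylic acid or a methoxy group in place of nitro might give a step beyond the scatter or might not. Also open, from the compounds shown here alone, is whether a nitro group elsewhere on the shared core, or a change at another part of that core, would matter more than this one does.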